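Methoxy in place of chloro: expected antiproliferative potency

The compounds below may be only part of what the source reports. "The series", "measured", "known", "first", "only" and "open" are said of these compounds alone.

Of the compounds shown here, two have numbers so far in a functional assay on MCF7 cells (Homo sapiens) for antiproliferative activity, read by MTT assay, with a stated time of 72 h; on this read-out higher numbers stand for weaker inhibition and lower numbers for stronger inhibition. Compound 1 `COc1ncc(-c2ccc3c(c2)N(c2ccc(F)cc2)C(=O)CO3)cc1NS(=O)(=O)c1ccc(F)cc1` is reported only as a limit of this assay, > 40000 nM. Compound 2 `O=C1COc2ccc(-c3cnc(Cl)c(NS(=O)(=O)c4ccc(F)cc4)c3)cc2N1C1CC1` gives 16700 nM in this assay. Among the measured compounds shown here, compound 2 therefore stands as the only measured number in this assay, since the other value is a limit (the limit of > 40000 nM in this assay, at which 1 of the 2 values shown sits); no ordering between the two can be drawn beyond that.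

Compound 3 `COc1ncc(-c2ccc3c(c2)N(C2CC2)C(=O)CO3)cc1NS(=O)(=O)c1ccc(F)cc1` is not yet measured. It differs from compound 2 by methoxy in place of chloro on an aromatic carbon, the change sitting on an aromatic carbon of a six-membered aromatic ring with 1 nitrogen. For the measured compounds named here, no pair of measured compounds differing in one place is available, so the size of this step has no precedent here. Compound 1 also carries the methoxy group, though it differs from compound 3 elsewhere, and compound 1 reached only the limit in this assay.

A step of a 1.8-fold higher number from compound 2 to compound 3 (0.25 log units; within the scatter) toward weaker inhibition is expected, though it may stay within the scatter. Compound 3 is estimated at 30000 nM, between 10000 nM and 90000 nM, with a real chance of a limit.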

Compound 3, half-maximal inhibitory concentration: 35200 nM
Compound 3: the middle estimate sits 1.2-fold (0.07 log units) below what was measured; the measured number falls inside the stated range.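

In this assay, among the compounds shown here, methoxy in place of chloro on the aromatic carbon next to the ring nitrogen now has a measured size: a 2.1-fold higher number from compound 2 to compound 3 (0.32 log units; beyond the scatter), a modest step and the first reading of a single change at this position. Cyclopropyl in place of 4-fluorophenyl on the amide-type nitrogen in a ring gives an at least 1.1-fold lower number from compound 1 to compound 3 (0.05 log units; that floor lies within the scatter), so the methoxy compounds show no separation beyond the scatter on that change. Compound 1 is reported as a limit and not a number, which leaves the size of that step open on one side: the limit of > 40000 nM in this assay, at which 1 of the 3 values shown sits.

From the compounds shown here alone, how a hydroxyl group, an amine or a longer alkoxy chain such as ethoxy would read at the position held by chloro and methoxy remains open. Also open, going by these compounds, are how 4-fluorophenyl and cyclopropyl on the amide-type nitrogen compare when chloro is present, and how a small alkyl group such as methyl would read on that nitrogen.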